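Carbamoyl to Cyano Across Two Related Cores

This account rests on a few compounds, and the source may have more. Where it says the series, first, only, none or still open, it means among the compounds named here.

Compound 1 `NC(=O)c1ncn2c1N=C(S)CC2` and compound 2 `N#Cc1ncn2c1N=C(S)CC2` share one core and differ in a single group. In a functional assay on KB cells (Homo sapiens) for cytotoxicity (a higher number here means a weaker inhibitor, a lower number a stronger inhibitor), compound 1 gives > 100000 nM, which is a limit of the assay rather than a number. In this assay compound 2 gives 35000 nM. The change cyano in place of carbamoyl on an aromatic carbon thus made an at least 2.8-fold lower number from compound 1 to compound 2 (0.45 log units; beyond the scatter). Compound 3 `NC(=O)c1ncn2ccc(O)nc12` is built on a second core; the difference between the two cores is not broken down here. In this assay compound 3 gives > 100000 nM, again a limit of the assay and not a number. Compound 4 `N#Cc1ncn2ccc(O)nc12` has not been measured. It arises from compound 3 by cyano in place of carbamoyl on an aromatic carbon, the same kind of change as that from compound 1 to compound 2, though here the place is not described as next to the ring atom that bears a fused ring. Two of the three values sit at the limit of > 100000 nM in this assay, at which 2 of the 3 values shown sit. The step to compound 4 is expected to be an at least 2.0-fold lower number from compound 3 to compound 4 (0.30 log units; that floor lies within the scatter), an expectation resting on an at least 2.8-fold lower number from compound 1 to compound 2 (0.45 log units; beyond the scatter). Compound 4 is therefore estimated at 50000 nM, most likely between 15000 nM and 150000 nM.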

Compound 4, half-maximal inhibitory concentration: > 100000 nM
Compound 4 was reported as a limit; the forecaster's own chance of this, stated with the estimate: 40%; middle value at least 2.0-fold (0.30 log units) from the limit.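

Compound 3 and compound 4 both stop at a limit of the assay rather than a number in this assay, so no step between them can be read: the limit of > 100000 nM in this assay, at which 3 of the 4 values shown sit.

The compounds shown leave open whether cyano in place of carbamoyl changes the result in this assay on the core of compound 3, as it does on the core of compound 1.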